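Removing One Fluoro from Compound 2

This account rests on a few compounds, and the source may have more. Where it says the series, first, only, none or still open, it means among the compounds named here.

In a functional assay on CCRF-CEM cells (Homo sapiens) for cytotoxicity, in the absence of a further agent (a higher number here means a weaker inhibitor, a lower number a stronger inhibitor), compound 1 `Nc1nc(N)c(CCCNc2cc(F)ccc2[N+](=O)[O-])c(O)n1` gives > 100000 nM as its reading, which is a limit of the assay and not a number. Going by the values given here, compound 2 `COC(=O)c1ccc(CN(CCCc2c(N)nc(N)nc2O)c2cc(F)c(F)cc2[N+](=O)[O-])cc1` gives 55000 nM in this assay and so holds the only true number so far. Compound 3 `COC(=O)c1ccc(CN(CCCc2c(N)nc(N)nc2O)c2cc(F)ccc2[N+](=O)[O-])cc1` is still unmeasured. It differs from compound 2 in one place, where 4,5-difluoro-2-nitrophenyl becomes 5-fluoro-2-nitrophenyl, with hydrogen in place of fluoro on an aromatic carbon and nothing else altered. Among the compounds with values here, no measured pair of compounds shows what this swap does on its own. The expected step of a 1.1-fold higher number from compound 2 to compound 3 (0.04 log units; within the scatter) in this assay is none beyond the usual scatter, with neither direction favoured. For compound 3 the estimated value is 60000 nM within an expected range of 25000 nM to 120000 nM in this read-out.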

Compound 3, half-maximal inhibitory concentration: 43000 nM
Beside the measured number, compound 3's estimate is 1.4-fold (0.14 log units) above it; low and high end bracket the measured number.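

Hydrogen in place of fluoro on this aromatic carbon, ortho to a fluoro group and meta to a nitro group, gives a 1.3-fold lower number from compound 2 to compound 3 (0.11 log units; within the scatter) in this assay, so this first measured pair shows no change beyond the scatter from the swap. Compound 3 also links it to compound 1 through one change, 4-(methoxycarbonyl)benzyl in place of hydrogen on a nitrogen on an aromatic ring, which gives an at least 2.3-fold lower number from compound 1 to compound 3 (0.36 log units; beyond the scatter). The reading of compound 1 is a limit and not a number, so the full size of that step stays unknown: the limit of > 100000 nM in this assay, at which 1 of the 3 values shown sits.

The compounds shown leave open what an amine or a methoxy group would do on this same carbon. They also leave open whether a carboxylic acid in place of the methyl ester would shift the reading in this assay.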